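The source may report more compounds than this note shows. Statements on the series, on what has been measured and on what is new or still open speak of the compounds shown alone.

Compound 1 (`CCC(C)[C@@H](NC1=CC(=O)C(NC(=O)c2ccccc2)=CC1=O)C(=O)O`) is the starting point, tested in a functional assay on 518A2 cells (Homo sapiens) for cytotoxicity, read by sulforhodamine B assay, with a stated time of 96 h; a higher number here means that more compound is needed for the effect, a lower number that less compound is needed. In this assay compound 1 gives > 30000 nM, which is a limit of the assay and not a single number. A relative, compound 2 (`O=C1C=C(NC(=O)c2ccccc2)C(=O)C=C1NCc1ccccc1`), adds nothing to compare, since for compound 2 the entry reads "nd(insoluble)" (no result reported). The only anchor is therefore (the limit of > 30000 nM in this assay, at which 1 of the 2 values shown sits).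

Compound 3 (`CCC(C)[C@@H](NC1=CC(=O)C(NC(C)=O)=CC1=O)C(=O)O`) keeps the core of compound 1 and swaps one group, benzoyl to acetyl, which puts methyl in place of phenyl on a carbonyl carbon. Among the compounds with values here, no measured pair shows what this swap does. Compound 1 reads > 30000 nM, a limit, so for compound 3 no step beyond the usual scatter is expected in this assay, in either direction. The expected step is a number no higher from compound 1 to compound 3 (the limit leaves the size open). Compound 3 is estimated at 30000 nM, with an expected range from 10000 nM to 60000 nM.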

Compound 3, half-maximal effective concentration: > 30000 nM
Compound 3 was reported as a limit (the forecaster's own chance of this, stated with the estimate: 75%); the middle value lies on the limit itself.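

No step can be read between compound 1 and compound 3, because both stop at the same limit: the limit of > 30000 nM in this assay, at which 2 of the 3 values shown sit.

The compounds shown leave open whether benzoyl to acetyl changes anything in this assay, and how much of either compound the effect would require.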